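The compounds below may be only part of what the source reports. "The series", "measured", "known", "first", "only" and "open" are said of these compounds alone.

Working notes on the series. In a functional assay on A549 cells (Homo sapiens) for antiproliferative activity, read by MTT assay, with a stated time of 48 h (a higher number here means a weaker inhibitor, a lower number a stronger inhibitor), compound 1 (`COc1ccc(/C=C/C(=O)Nc2cc3c(Nc4ccc(Cl)c(Cl)c4)ncnc3s2)cc1`) gives 3320 nM and compound 2 (`COc1ccc(/C=C/C(=O)Nc2cc3c(Nc4cc(Cl)cc(Cl)c4)ncnc3s2)cc1`) gives 21900 nM. Going by the values given here, compound 2 therefore holds the higher of the only two numbers available, which makes it the weaker inhibitor of the pair. Among the compounds with values here, the one measured step is a 6.6-fold higher number from compound 1 to compound 2 (0.82 log units; beyond the scatter), with 3,5-dichlorophenyl in place of 3,4-dichlorophenyl on a nitrogen.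

Compound 3 (`O=C(/C=C/c1ccccc1)Nc1cc2c(Nc3cc(Cl)cc(Cl)c3)ncnc2s1`) keeps the 3,5-dichlorophenyl group of compound 2 and carries hydrogen in place of methoxy on an aromatic carbon, para to a large group, so that 4-methoxyphenyl becomes phenyl: hydrogen in place of methoxy on an aromatic carbon. The measured step lies at a different place in the molecule and gives no direct size for this change. It shows only that a single substitution in this series can move the number beyond the scatter. No direction can be drawn from it, so no step beyond the scatter is expected in this assay, though with low confidence.

The expected step is a 1.1-fold lower number from compound 2 to compound 3 (0.04 log units; within the scatter). For compound 3 the estimate is 20000 nM, with an expected range of 8000 nM to 50000 nM.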

Compound 3, half-maximal inhibitory concentration: 40 nM
Estimate against measurement, compound 3: 500-fold (2.70 log units) above; the measured number lies below the stated range.
By their numbers in this assay, from the lowest: compound 3; then compound 1; then compound 2.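

In this assay, going by these compounds alone, hydrogen in place of methoxy on the aromatic carbon para to a large group gives a 550-fold lower number from compound 2 to compound 3 (2.74 log units; beyond the scatter), a larger move than the one at the dichlorophenyl group, a 6.6-fold higher number from compound 1 to compound 2 (0.82 log units; beyond the scatter). The number in this series therefore responds strongly to the 4-methoxyphenyl to phenyl change at the far end of the 2-phenylethenyl arm, and not only to the chlorine pattern on the group carried by the nitrogen. No measurement available here accounts for the size of this step.

The compounds shown leave open whether the same change would move the number as far with the 3,4-dichlorophenyl group of compound 1, since only the 3,5-dichlorophenyl pair of compound 2 and compound 3 carries this comparison. They also leave open whether the step belongs to methoxy alone or extends to other groups on that aromatic carbon, such as fluorine, methyl, hydroxyl or ethoxy, and whether methoxy elsewhere on the same phenyl ring would cost as much.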